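Sulfonamide to trifluoroacetamide swap on the shared core

The source may report more compounds than this note shows. Statements on the series, on what has been measured and on what is new or still open speak of the compounds shown alone.

Measured so far, a single assay:
compound 1 `CC(C)S(=O)(=O)Nc1cccc2c1CCCC2c1c[nH]cn1`: < 10000 nM, a limit
compound 2 `O=S(=O)(Nc1cccc2c1CCCC2c1c[nH]cn1)C1CC1`: < 10000 nM, a limit
compound 3 `CN(C)S(=O)(=O)Nc1cccc2c1CCCC2c1c[nH]cn1`: < 10000 nM, a limit

Compound 3 stands at the assay limit in an assay on isolated protein (Cricetulus griseus) for binding affinity to Alpha-1B adrenergic receptor (Mesocricetus auratus), read by radioligand binding; on this read-out higher numbers stand for weaker inhibition and lower numbers for stronger inhibition; its value is not a number. The steps among the measured compounds, a step that the two limits leave unreadable from compound 1 to compound 2, a step that the two limits leave unreadable from compound 1 to compound 3 and a step that the two limits leave unreadable from compound 2 to compound 3, are all unreadable in size because of the limit of < 10000 nM in this assay, at which 3 of the 3 values shown sit. Compound 4 `O=C(Nc1cccc2c1CCCC2c1c[nH]cn1)C(F)(F)F` differs from compound 3 by (trifluoromethyl)carbonyl in place of dimethylsulfamoyl on a nitrogen on an aromatic ring. Within the data shown here, none of the measured steps touches this part of the shared core, so no direction or size for the change can be read from them. Among the measured compounds shown here, the step that the limit leaves unreadable from compound 3 to compound 4 is therefore an estimate resting on no measured step. Compound 4 is expected at about 2000 nM, within 200 nM to 10000 nM.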

Compound 4, inhibition constant: < 10000 nM
Compound 4 gave a limit, no number (the forecaster's own chance of this, stated with the estimate: 50%); the middle value does not contradict the limit.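

No step between compound 4 and compound 1, compound 2 or compound 3 can be read in this assay, because each compound gives only a limit: the limit of < 10000 nM in this assay, at which 4 of the 4 values shown sit.

The compounds shown leave open whether the group on the aromatic nitrogen changes the read-out at all, and in which direction.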